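The source may hold more compounds than are shown below. What is called first, only, known or untested is meant among the compounds shown, and "the series" means these compounds.

Measured in a functional assay on DU-145 cells (Homo sapiens) for inhibition, read by trypan blue exclusion, with a stated time of 96 h; a lower number here means a stronger inhibitor of growth, a higher number a weaker inhibitor of growth:

- compound 1, `O=C(/C(=C\c1ccccc1OCc1ccccc1)SCc1ccc(Cl)c(Cl)c1)c1ccc(Cl)cc1`: compound 1 gives 10000 nM
- compound 2, `Cc1ccc(S/C(=C/c2sccc2C)C(=O)c2ccc(Br)cc2)cc1`: compound 2 gives 50000 nM
- compound 3, `Cc1ccc(S(=O)(=O)/C(=C/c2cccs2)C(=O)c2ccc(Cl)cc2)cc1`: compound 3 gives 25000 nM

All three numbers are high, so the series as a whole is a weak inhibitor of growth in this assay. Compound 3 stands second highest of the three. Its nearest neighbour is compound 2, whose number is higher but within the scatter, so no order between compound 2 and compound 3 can be read. Its furthest is compound 1, whose number is lower and beyond the scatter; compound 1 is the only one of the three that clearly inhibits growth more than compound 3.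

Compound 4, `Cc1ccc(S(=O)(=O)/C(=C/c2cc(C)ccc2C)C(=O)c2ccc(Cl)cc2)cc1`, is not yet measured. It differs from compound 3 in one place: 2,5-dimethylphenyl in place of thiophen-2-yl on a double-bonded chain carbon bound to a double-bonded chain carbon. The thiophen-2-yl leaves and the 2,5-dimethylphenyl enters on the double-bonded chain carbon. Among the measured compounds shown here, no step between measured compounds covers this change, so nothing in the data fixes its size. The expectation in this assay is a small step, downward if anything, and not clearly beyond the scatter; the step from compound 3 to compound 4 is estimated as a 1.3-fold lower number from compound 3 to compound 4 (0.10 log units; within the scatter). Compound 4 is expected to give about 20000 nM, within 6000 nM to 60000 nM.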

Compound 4, concentration for 50% growth inhibition: 1000 nM
For compound 4 the middle estimate is 20-fold (1.30 log units) above the measured one, and the stated range ends above it.
By their numbers in this assay, from the lowest: compound 4; then compound 1; then compounds 3 and 2 (each within the scatter of the next).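

In this assay, among the compounds shown here, this is the first single change that can be read, and it falls on a double-bonded chain carbon bound to a double-bonded chain carbon: 2,5-dimethylphenyl in place of thiophen-2-yl gives a 25-fold lower number from compound 3 to compound 4 (1.40 log units; beyond the scatter), a large step. The two compounds differ nowhere else, so this position is sensitive to the group it carries. No measurement at hand accounts for the size of the step.

As far as these compounds go, whether the step belongs to the six-membered ring itself or to its two methyl groups stays open; a plain phenyl or a 2-methylphenyl at this place would separate the two. Also open, from the compounds shown here alone, is whether the same exchange holds with a thioether in place of the sulfonyl group.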